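The source may hold more compounds than are shown below. What is called first, only, known or untested is meant among the compounds shown, and "the series" means these compounds.

Measured compounds:
- compound 1, `O=C(OCc1ccccc1)[C@H]1O[C@@H](Oc2cc3oc(-c4ccc(O)cc4)cc(=O)c3c(O)c2O)[C@H](O)[C@@H](O)[C@@H]1O`, in an ADME assay on a cell-free system (plasma, Homo sapiens) for metabolic stability (a lower number here means that the compound disappears faster, a higher number that the compound lasts longer), compound 1 gives 1.47 h
- compound 2, `C[C@H](NC(=O)[C@H](N)CCC(=O)OCCc1ccccc1)C(=O)O`, in this assay compound 2 gives 1.62 h

Of the two numbers, that of compound 1 is the smaller, yet its distance from compound 2 is within the scatter, so the two cannot be told apart on these data. Going by the values given here, the two compounds also share no common core, and no pair that differs in a single place has been measured, so nothing is known yet about how a single change moves the number in this assay.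

Among the compounds with values here, compound 3, `CCN(CC)C(=O)COC(=O)[C@H]1O[C@@H](Oc2cc3oc(-c4ccc(O)cc4)cc(=O)c3c(O)c2O)[C@H](O)[C@@H](O)[C@@H]1O`, is the first such pair: it keeps the whole core of compound 1 and changes one place, (diethylcarbamoyl in place of phenyl on a saturated chain carbon bound to an oxygen next to a carbonyl group). Within the data shown here, since no measured step exists to lean on, the expectation rests on compound 1 alone. For this assay a step of modest size is expected, pointing towards a shorter half-life, though a result within the scatter of compound 1 cannot be ruled out. Compound 3 is therefore estimated to give 0.7 h, within a range from 0.2 h to 2.5 h, which would mean an expected step of a 2.1-fold lower number from compound 1 to compound 3 (0.32 log units; beyond the scatter).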

Compound 3, half-life: 0.167 h
Beside the measured number, compound 3's estimate is 4.2-fold (0.62 log units) above it; the measured number lies below the stated range.
By their numbers in this assay, from the lowest: compound 3; then compounds 1 and 2 (each within the scatter of the next).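

In this assay, putting diethylcarbamoyl in place of phenyl on a saturated chain carbon bound to an oxygen next to a carbonyl group gives an 8.8-fold lower number from compound 1 to compound 3 (0.94 log units; beyond the scatter). Going by these compounds alone, this is the first sign that a single change at this place on the shared core can move the half-life well beyond the scatter, and here it moves towards faster disappearance. The change swaps a six-membered aromatic ring of carbon only for a group with no ring that brings in nitrogen, a double bond and a hydrogen-bond acceptor, and nothing measured here shows which of these differences accounts for the shorter half-life.

The compounds shown leave open whether the number falls with the loss of the phenyl ring or with the arrival of the diethylcarbamoyl group. At this same place, a plain longer carbon chain, a cyclohexyl ring, an amine or a carboxylic acid could help to separate those two readings, and the same is true of a dimethylcarbamoyl group, which would show whether the size of the groups on the nitrogen matters.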